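Triazole in Place of Pyridine on the Benzylic Ring

The compounds below may be only part of what the source reports. "The series", "measured", "known", "first", "only" and "open" are said of these compounds alone.

Compound 1 `Cc1cc(C)c(NC(=O)N(Cc2ccc(-c3ccccn3)cc2)C2CCCCCC2)c(C)c1`: 33 nM
Compound 2 `Cc1cc(C)c(NC(=O)N(Cc2cccc(-c3cn[nH]c3)c2)C2CCCCCC2)c(C)c1`: 38 nM

Of the compounds shown here, two have been measured in an assay on microsomes from intestine for inhibition of acyl-CoA:cholesterol acyltransferase (Oryctolagus cuniculus); a higher number here means a weaker inhibitor, a lower number a stronger inhibitor. Compound 1 gives 33 nM, the lower of the two numbers. Compound 2 gives 38 nM; the two values lie within the usual scatter of each other, so neither can be called the stronger inhibitor. Compound 3 `Cc1cc(C)c(NC(=O)N(Cc2ccc(-n3ccnn3)cc2)C2CCCCCC2)c(C)c1` has not yet been measured. It differs from compound 1 in one place: 1H-1,2,3-triazol-1-yl in place of pyridin-2-yl on an aromatic carbon. For the measured compounds named here, no measured pair isolates exactly this change, so there is no step to lean on directly. The closeness of compounds 1 and 2, which carry different five- or six-membered heterocycles on the shared core, suggests that this region tolerates variation. A small weakening, or no change beyond the scatter, is expected for the step of a 1.7-fold higher number from compound 1 to compound 3 (0.22 log units; within the scatter). Compound 3 is estimated at 55 nM, most likely between 20 nM and 160 nM.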

Compound 3, half-maximal inhibitory concentration: 42 nM
The estimate for compound 3 lay 1.3-fold (0.12 log units) above the measured number; the range from low to high includes it.
By their numbers in this assay, from the lowest: compounds 1, 2 and 3 (each within the scatter of the next).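

Placing 1H-1,2,3-triazol-1-yl instead of pyridin-2-yl on the aromatic carbon para to a large group gives, in this assay, a 1.3-fold higher number from compound 1 to compound 3 (0.10 log units; within the scatter), the first comparison here that isolates a single change at this position. A five-membered aromatic ring with 3 hetero atoms and 3 hydrogen-bond acceptors can therefore stand where a six-membered aromatic ring with 1 hetero atom and 1 hydrogen-bond acceptor stood, with no difference that can be read. No measurement at hand bears on why these two rings give such close numbers.

On these data alone, both groups are aromatic rings, so it remains open whether this tolerance extends to a group without a ring, such as a carboxylic acid or a simple amine. A plain hydrogen at this position would show whether any ring is needed there at all.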